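A few compounds are considered here, and "the series" means these few. Any claim that something is new, unique, unknown or untested is made for them only; others in the source may bear on it.

Among the measured compounds shown here, in a functional assay on HT-1080 cells (Homo sapiens) for antiproliferative activity, read by MTT assay, with a stated time of 72 h (a lower number here means a stronger inhibitor, a higher number a weaker inhibitor), compound 3 (`COc1ccc(-c2sccc2-c2cc(OC)c(OC)c(OC)c2)cc1[N+](=O)[O-]`) gives 2100 nM, the lowest of the three numbers so far. Compound 2 (`COc1ccc(-c2sc(C(=O)O)cc2-c2cc(OC)c(OC)c(OC)c2)cc1O`) gives 7510 nM, and compound 1 (`CCOC(=O)c1cc(-c2cc(OC)c(OC)c(OC)c2)c(-c2ccc(OC)c([N+](=O)[O-])c2)s1`) gives 12700 nM. The next step leads to compound 4 (`COc1ccc(-c2sccc2-c2cc(OC)c(OC)c(OC)c2)cc1O`), with hydroxy in place of nitro on an aromatic carbon, ortho to a methoxy group: hydroxy in place of nitro on an aromatic carbon.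

For the measured compounds named here, no measured pair isolates this change. Going by the values given here, the only single-place step, hydrogen in place of ethoxycarbonyl, is a 6.0-fold lower number from compound 1 to compound 3 (0.78 log units; beyond the scatter), and it lies at a different site. Compound 2 carries the hydroxy but differs from compound 1 in two places, and their values stand within the scatter of each other, so the hydroxy shows no penalty there. This evidence is indirect, and the direction remains uncertain. A modest move to a lower number is expected in this assay, as the estimated 3.0-fold lower number from compound 3 to compound 4 (0.48 log units; beyond the scatter). Compound 4 is estimated at 700 nM, with an expected range of 80 nM to 3500 nM.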

Compound 4, half-maximal inhibitory concentration: 1940 nM
Estimate against measurement, compound 4: 2.8-fold (0.44 log units) below, and the stated range covers the measured number.
By their numbers in this assay, from the lowest: compounds 4 and 3 (each within the scatter of the next); then compounds 2 and 1 (each within the scatter of the next).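

In this assay hydroxy in place of nitro on this aromatic carbon, ortho to a methoxy group, gives a 1.1-fold lower number from compound 3 to compound 4 (0.03 log units; within the scatter) and so this assay does not separate the two groups on this core. With the hydroxy held constant, hydrogen in place of carboxy gives a 3.9-fold lower number from compound 2 to compound 4 (0.59 log units; beyond the scatter) and this runs in the same direction as hydrogen in place of ethoxycarbonyl with the nitro held constant, a 6.0-fold lower number from compound 1 to compound 3 (0.78 log units; beyond the scatter) so in both pairs the number falls when the substituent is replaced by hydrogen. Nothing measured here accounts for either result.

From the compounds shown here alone, whether an amine or a fluorine on this aromatic carbon would also stay within the scatter of nitro and hydroxy remains open. Also open, going by these compounds, is whether nitro and hydroxy stay equivalent when carboxy or ethoxycarbonyl is present on the core.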